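Cyclic amine swap at the aminomethyl position

The compounds below may be only part of what the source reports. "The series", "measured", "known", "first", "only" and "open" are said of these compounds alone.

Compound 1 `CCCN(CCC(F)(F)F)Cc1c(C(F)(F)F)nc2n(-c3c(C)cc(C)cc3C)c(Cl)cn12` and compound 2 `CCCN(Cc1c(C(F)(F)F)nc2n(-c3c(C)cc(C)cc3C)c(Cl)cn12)CC1CCC1` carry open-chain dialkylamino groups on the saturated chain carbon bound to an aromatic carbon of the shared core. In an assay on cells for displacement of a labelled ligand from corticotropin-releasing factor receptor 1 (Homo sapiens), with a stated time of 100 min (on this read-out lower numbers stand for stronger inhibition and higher numbers for weaker inhibition), compound 1 gives 12 nM. In this assay compound 2 gives 5.3 nM, the step being a 2.3-fold lower number from compound 1 to compound 2 (0.35 log units; beyond the scatter). Compound 3 `Cc1cc(C)c(-n2c(Cl)cn3c(CN4CCCC4c4ccccc4)c(C(F)(F)F)nc23)c(C)c1` sits at the weak end of the three. In this assay compound 3 reaches only the limit > 7000 nM, which is a limit of the assay and not a number (the limit of > 7000 nM in this assay, at which 1 of the 3 values shown sits). The two steps into this ring amine are an at least 580-fold higher number from compound 1 to compound 3 (2.76 log units; beyond the scatter) and an at least 1300-fold higher number from compound 2 to compound 3 (3.12 log units; beyond the scatter), both large. Compound 4 `Cc1cc(C)c(-n2c(Cl)cn3c(CN4CCCC(C)C4)c(C(F)(F)F)nc23)c(C)c1` differs from compound 3 by 3-methylpiperidin-1-yl in place of 2-phenylpyrrolidin-1-yl on a saturated chain carbon bound to an aromatic carbon. Both large steps bear on this change, since each introduced the 2-phenylpyrrolidin-1-yl group that now leaves; the entering ring keeps the cyclic amine but drops the six-membered aromatic ring of carbon only. A lower number than the limit of compound 3 is therefore expected, of uncertain size. Compound 4 is estimated at 150 nM, between 20 nM and 2000 nM, an expected step of an at least 46-fold lower number from compound 3 to compound 4 (1.66 log units; beyond the scatter).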

Compound 4, inhibition constant: 5800 nM
Beside the measured number, compound 4's estimate is 39-fold (1.59 log units) below it, and the stated range ends below it.
By their numbers in this assay, from the lowest: compound 2; then compound 1; then compound 4. At a limit, above all of these: compound 3.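

In this assay the change from open-chain amines to 3-methylpiperidin-1-yl gives a 1100-fold higher number from compound 2 to compound 4 (3.04 log units; beyond the scatter) and a 480-fold higher number from compound 1 to compound 4 (2.68 log units; beyond the scatter), and the change from 2-phenylpyrrolidin-1-yl gives an at least 1.2-fold lower number from compound 3 to compound 4 (0.08 log units; that floor lies within the scatter), so a large loss also comes with a ring amine lacking the six-membered aromatic ring of carbon only. The loss seen with compound 3 therefore does not depend on the 2-phenylpyrrolidin-1-yl group, and among the four compounds shown both ring amines lie far on the weak side of both open-chain amines. Compound 3 stands at a limit, which is not a number: the limit of > 7000 nM in this assay, at which 1 of the 4 values shown sits.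

On these data alone, whether an unsubstituted piperidine or a morpholine at this place would sit nearer the open-chain amines or the ring amines remains open. The compounds shown also do not separate ring closure itself from the identity of the groups on the amine nitrogen.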